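The source may report more compounds than this note shows. Statements on the series, on what has been measured and on what is new or still open speak of the compounds shown alone.

Of the compounds shown here, three built on one shared core have been measured in an in vitro ADME assay on microsomes from liver (Homo sapiens) for metabolic stability; on this read-out higher numbers stand for a longer-lived compound and lower numbers for a shorter-lived compound. Compound 1 `COc1ccc(-c2cc(-c3cccc(S(C)(=O)=O)c3)cnc2N)cn1` gives 3.78 h in this assay. Compound 2 `CNS(=O)(=O)c1ccc(-c2cnc(N)c(-c3ccc(OC)nc3)c2)cc1` gives 3.02 h. Compound 3 `COc1ccc(-c2cc(-c3ccc4nccn4c3)cnc2N)cn1` gives 2.43 h. Compound 2 thus sits within the scatter of both compound 1 and compound 3, so none of the three can be told apart on this read-out. Compound 4 `COc1ccc(-c2cc(-c3ccc(C(N)=O)cc3)cnc2N)cn1` has not yet been measured; compared with compound 2 it carries carbamoyl in place of methylsulfamoyl on an aromatic carbon. Among the compounds with values here, no measured pair shows this same change, so nothing in the data points to a move beyond the scatter in either direction. Compound 4 is therefore expected to give about 3 h, somewhere between 1.8 h and 5 h. The expected step of a 1.0-fold lower number from compound 2 to compound 4 (0.00 log units; within the scatter) stays within the scatter.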

Compound 4, half-life: > 4.16 h
Compound 4: no number, only a limit (the forecaster's own chance of this, stated with the estimate: 5%); middle value at least 1.3-fold (0.14 log units) away from the limit.
By their numbers in this assay, from the lowest: compounds 3, 2 and 1 (each within the scatter of the next). At a limit, above all of these: compound 4.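

Compound 4 gives no number in this assay, only a limit of the assay: the limit of > 4.16 h in this assay, at which 1 of the 4 values shown sits. Carbamoyl in place of methylsulfamoyl on this aromatic carbon gives an at least 1.3-fold higher number from compound 2 to compound 4 (0.13 log units; that floor lies within the scatter), so the change shows no sign of a shorter half-life, though its floor alone does not separate the pair. Within the data shown here, this is the first pair here that differs in one place only. Going by these compounds, the true half-life of compound 4 stays open, as does whether a carboxylic acid or an amine on this carbon would match carbamoyl.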